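A few compounds are considered here, and "the series" means these few. Any claim that something is new, unique, unknown or untested is made for them only; others in the source may bear on it.

Measured so far in an assay on isolated protein for displacement of a labelled ligand from Oxytocin receptor (Homo sapiens); a lower number here means a stronger inhibitor, a higher number a weaker inhibitor: compound 1 `Cc1ccc([C@H](C(=O)N(C)C)N2C(=O)[C@@H](C3Cc4ccccc4C3)NC(=O)[C@H]2CC(C)C)cn1` gives 1.59 nM; compound 2 `CC(C)C[C@@H]1C(=O)N[C@H](C2Cc3ccccc3C2)C(=O)N1[C@@H](C(=O)N(C)C)c1ccc(O)nc1` gives 3.16 nM; compound 3 `COc1ccc([C@H](C(=O)N2CCOCC2)N2C(=O)[C@@H](C3Cc4ccccc4C3)NC(=O)[C@H]2CC(C)C)cn1` gives 0.251 nM.

Compound 3 stands lowest of the three numbers, beyond the scatter from both others. Compound 4 `COc1ccc([C@H](C(=O)N(C)C)N2C(=O)[C@@H](C3Cc4ccccc4C3)NC(=O)[C@H]2CC(C)C)cn1` carries the change (dimethylamino in place of morpholin-4-yl on a carbonyl carbon). For the measured compounds named here, no measured step covers this change directly: the only single-point step, a 2.0-fold higher number from compound 1 to compound 2 (0.30 log units; within the scatter), concerns a different position and lies within the scatter. Compound 1 differs from compound 3 in two places, one of them this same amide change, and its number is the higher one, so compound 4 is expected to fall between those two. The estimate is a 3.2-fold higher number from compound 3 to compound 4 (0.50 log units; beyond the scatter), giving compound 4 an expected 0.8 nM, with a range from 0.3 nM to 2.5 nM.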

Compound 4, inhibition constant in the Oxytocin receptor assay: 0.398 nM
Compound 4: middle estimate off by 2.0-fold (0.30 log units), on the high side; low and high end bracket the measured number.
By their numbers in the Oxytocin receptor assay, from the lowest: compounds 3 and 4 (each within the scatter of the next); then compounds 1 and 2 (each within the scatter of the next).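

Swapping morpholin-4-yl for dimethylamino on a carbonyl carbon is tolerated: in the Oxytocin receptor assay the result is a 1.6-fold higher number from compound 3 to compound 4 (0.20 log units; within the scatter), and in a physicochemical assay for lipophilicity, read by HPLC (on this read-out higher numbers stand for higher lipophilicity and lower numbers for lower lipophilicity), it is no change at the digits printed from compound 3 to compound 4 (within the scatter), with compound 3 at 2.7 and compound 4 at 2.7. With dimethylamino held fixed, the aromatic group does matter in the Oxytocin receptor assay, with a 4.0-fold lower number from compound 1 to compound 4 (0.60 log units; beyond the scatter) for methoxy in place of methyl and a 7.9-fold lower number from compound 2 to compound 4 (0.90 log units; beyond the scatter) for methyl in place of hydrogen on an oxygen on an aromatic ring. No evidence on hand explains these steps.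

Still open, from the compounds shown here alone, is how diethylamino or piperazin-1-yl on this carbonyl carbon would read. Also open, going by these compounds, is whether morpholin-4-yl would give the same result alongside methyl on the aromatic ring.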